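Ester tail variation and intestinal microsomal half-life

A few compounds are considered here, and "the series" means these few. Any claim that something is new, unique, unknown or untested is made for them only; others in the source may bear on it.

compound 1 `CCCOC(=O)/C=C/c1ccc(NC(=O)C2(NC(=O)c3ccc4c(C5CCCC5)c(-c5ncc(Cl)cn5)n(C)c4c3)CCC2)cc1OCC` — > 5 h
compound 2 `CCOc1cc(NC(=O)C2(NC(=O)c3ccc4c(C5CCCC5)c(-c5ncc(Cl)cn5)n(C)c4c3)CCC2)ccc1/C=C/C(=O)OCC(C)C` — > 5 h

In an ADME assay (intestine, Homo sapiens) for pharmacokinetics, using microsomes (a lower number here means that the compound disappears faster, a higher number that the compound lasts longer), compound 1 reaches > 5 h, which is a limit of the assay rather than a number. Compound 2 likewise sits at > 5 h, again a limit. The step that the two limits leave unreadable from compound 1 to compound 2 thus stays unreadable; both values rest on (the limit of > 5 h in this assay, at which 2 of the 2 values shown sit). Compound 3 `CCOc1cc(NC(=O)C2(NC(=O)c3ccc4c(C5CCCC5)c(-c5ncc(Cl)cn5)n(C)c4c3)CCC2)ccc1/C=C/C(=O)OCc1ccccc1` differs from compound 2 by phenyl in place of isopropyl on a saturated chain carbon bound to an oxygen next to a carbonyl group. For the measured compounds named here, no measured step bears on this change, and the measured values give only the limit. Compound 3 is therefore expected to remain at the limit, the expected step of a number no higher from compound 2 to compound 3 (the limit leaves the size open) meaning no readable change. The estimate for compound 3 is 5 h, in the range 2 h to 10 h.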

Compound 3, half-life: > 5 h
Compound 3 ended at the assay's limit; the forecaster's own chance of this, stated with the estimate: 60%; the middle value sits exactly at the limit.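

Compound 1, compound 2 and compound 3 all rest at a limit in this assay, so no step among them can be read: the limit of > 5 h in this assay, at which 3 of the 3 values shown sit.

The compounds shown leave open whether the ester tail affects half-life at all.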